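Substituent on the anilide ring and acid dissociation

The source may hold more compounds than are shown below. What is called first, only, known or untested is meant among the compounds shown, and "the series" means these compounds.

Compound 3 `N#C/C(=N\O)C(=O)Nc1ccccc1` is the unsubstituted anilide of this series. In a physicochemical assay for acid dissociation, using potentiometric titration, compound 3 gives 5.12; compound 1 `N#C/C(=N\O)C(=O)Nc1cccc(C(F)(F)F)c1` gives 4.88 and compound 2 `N#C/C(=N\O)C(=O)Nc1ccccc1F` gives 4.87, so all three numbers lie within the scatter of one another and none can be placed above or below the rest. The two steps onto compound 3 were a number 0.24 log units higher from compound 1 to compound 3 (within the scatter) and a number 0.25 log units higher from compound 2 to compound 3 (within the scatter).

Compound 4 `N#C/C(=N\O)C(=O)Nc1ccc(-c2ccccc2)cc1` carries phenyl in place of hydrogen on an aromatic carbon. For the measured compounds named here, no measured step involves phenyl in place of hydrogen on an aromatic carbon, so the two steps onto compound 3 are the only guide, and both changes on that ring left the acid dissociation constant unchanged beyond the scatter. Compound 4 is therefore expected to show a number 0.07 log units lower from compound 3 to compound 4 (within the scatter), a step no larger than the scatter. The estimate for compound 4 in this assay is 5.05, with a range from 4.75 to 5.35.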

Compound 4, acid dissociation constant: 5.03
Estimate against measurement, compound 4: 0.02 log units above; the range from low to high includes it.
By their numbers in this assay, from the lowest: compounds 2, 1, 4 and 3 (each within the scatter of the next).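

In this assay, the step reads a number 0.09 log units lower from compound 3 to compound 4 (within the scatter), so phenyl, with its 6 heavy atoms, on an aromatic carbon para to a group of 8 heavy atoms gives a step that stays inside the scatter. For the compounds shown here, this is the first step at this place on the ring and the first in which a whole six-membered aromatic ring enters, and it joins the trifluoromethyl and fluoro steps in lying within the scatter, with no compound of the four going against that. Nothing in the data available here offers an explanation for this result.

The compounds shown leave open whether an amine or a carboxylic acid at this place would give a step beyond the scatter. They also leave open whether a longer chain there would stay within it.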